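Swapping benzofuran for furan on a ribose-bearing core

The source may report more compounds than this note shows. Statements on the series, on what has been measured and on what is new or still open speak of the compounds shown alone.

Four compounds share one core, a fused two-ring system carrying a sugar-like 3,4-dihydroxy-5-(hydroxymethyl)oxolan-2-yl group, and differ only in two places. Compound 1 is `Cc1nc(N)c2c(-c3ccco3)cn([C@@H]3O[C@H](CO)[C@@H](O)[C@H]3O)c2n1`, compound 2 is `Cc1nc(N)c2c(-c3cc4ccccc4o3)cn([C@@H]3O[C@H](CO)[C@@H](O)[C@H]3O)c2n1`, compound 3 is `Nc1nc(N)c2c(-c3cc4ccccc4o3)cn([C@@H]3O[C@H](CO)[C@@H](O)[C@H]3O)c2n1`, and compound 4, not yet measured, is `Nc1nc(N)c2c(-c3ccco3)cn([C@@H]3O[C@H](CO)[C@@H](O)[C@H]3O)c2n1`.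

All three measured compounds were tested in a functional assay on A549 cells (Homo sapiens), read by MTT assay, with a stated time of 72 h; a higher number here means a weaker inhibitor, a lower number a stronger inhibitor. Compound 1 reached only a limit of the assay, > 20000 nM. Compound 2 likewise gave only a limit, > 20000 nM. Compound 3 also gave only a limit, > 20000 nM. Because of this, (the limit of > 20000 nM in this assay, at which 3 of the 3 values shown sit), the steps between them cannot be read: the step that the two limits leave unreadable from compound 2 to compound 1, which is the change (furan-2-yl in place of 1-benzofuran-2-yl on an aromatic carbon), and the step that the two limits leave unreadable from compound 2 to compound 3, which is the change (amino in place of methyl on an aromatic carbon), both stay unreadable.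

The same kind of change, (furan-2-yl in place of 1-benzofuran-2-yl on an aromatic carbon), carries compound 3 to compound 4; the place around it is the same as for the pair already measured. Since compound 1 with the furan-2-yl group already sits at the limit, and compound 3 with the amino group does too, compound 4 is expected to reach the same limit, so the step that the limit leaves unreadable from compound 3 to compound 4 is estimated to be close to nothing. For compound 4 the expected value in this assay is 40000 nM, with a range estimated from 15000 nM to 150000 nM.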

Compound 4, half-maximal inhibitory concentration: > 20000 nM
Compound 4 ended at the assay's limit (the forecaster's own chance of this, stated with the estimate: 90%); the middle value is on the limit's open side.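

Neither new step can be read, neither the one from compound 3 to compound 4 nor the one from compound 1 to compound 4, because all of these compounds stop at the same limit: the limit of > 20000 nM in this assay, at which 4 of the 4 values shown sit.

The compounds shown leave open whether swapping 1-benzofuran-2-yl for furan-2-yl, or methyl for amino, changes the strength of inhibition at all in this assay.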